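This account rests on a few compounds, and the source may have more. Where it says the series, first, only, none or still open, it means among the compounds named here.

Working notes on the series, all read in a functional assay on MDA-MB-231 cells (Homo sapiens) for inhibition, read by MTT assay, with a stated time of 48 h; on this read-out higher numbers stand for weaker inhibition and lower numbers for stronger inhibition. For the measured compounds named here, compound 2 (`COc1ccc(N(C)c2nc(C)nc3ccccc23)cc1[Se]C#N`) gives 52 nM, the lowest of the two numbers so far, while compound 1 (`COc1ccc(N(C)c2nc(C)nc3ccccc23)cc1C(=O)OCCC[Se]C#N`) gives 1180 nM. Compound 3 (`COc1ccc(N(C)c2nc(C)nc3ccccc23)cc1C[Se]C#N`) keeps the shared core and alters one place: a group of 4 heavy atoms (2 carbon, 1 nitrogen, 1 selenium; no ring) in place of a group of 3 heavy atoms (1 carbon, 1 nitrogen, 1 selenium; no ring), on an aromatic carbon. That place is ortho to a methoxy group and meta to a large group. Going by the values given here, only one measured step bears on this change: a 23-fold lower number from compound 1 to compound 2 (1.36 log units; beyond the scatter), which is large and involves a much bigger group at the same place. The group in compound 3 is far closer in heavy-atom count to that of compound 2, so a moderate move to a higher number is expected, well short of that large step. One step is thin evidence, so the range stays wide. The expected step is a 2.5-fold higher number from compound 2 to compound 3 (0.40 log units; beyond the scatter). For compound 3 the estimated value is 130 nM, with an expected range of 40 nM to 500 nM.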

Compound 3, half-maximal inhibitory concentration: 153 nM
Compound 3: middle estimate off by 1.2-fold (0.07 log units), on the low side; measured number inside the range.
By their numbers in this assay, from the lowest: compound 2; then compound 3; then compound 1.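

In this assay, the place on an aromatic carbon, ortho to a methoxy group and meta to a large group, responds even to a small change in group size: the group of 4 heavy atoms gives a 2.9-fold higher number from compound 2 to compound 3 (0.47 log units; beyond the scatter). That same group, in place of the group of 9 heavy atoms, gives a 7.7-fold lower number from compound 1 to compound 3 (0.89 log units; beyond the scatter), so across these three compounds the number rises with the heavy-atom count of the group, and no compound shown goes against that order. Nothing measured here gives a reason for either step.

Still open, as far as these compounds go, is whether a longer chain without a carbonyl would follow the same order. From the compounds shown here alone, how an amine or a carboxylic acid at this place would read is also open.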